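A benzylpyrrolidine in place of the dimethylaminomethyl group

The source may hold more compounds than are shown below. What is called first, only, known or untested is meant among the compounds shown, and "the series" means these compounds.

Compound 1 `CN(C)CC(=O)N1CCC(NS(=O)(=O)c2cc(S(=O)(=O)c3ccccc3)ccc2C(F)(F)F)CC1` gives the highest of the three numbers in an assay on isolated protein for binding affinity to secreted frizzled-related protein 1 (Homo sapiens), read by fluorescence (a higher number here means a weaker inhibitor, a lower number a stronger inhibitor), with a value of 300 nM. Compound 2 `CC(=O)N1CCC[C@H]1C(=O)N1CCC(NS(=O)(=O)c2cc(S(=O)(=O)c3ccccc3)ccc2C(F)(F)F)CC1` gives 160 nM in this assay, and compound 3 `CC(C)C(=O)N1CCC[C@H]1C(=O)N1CCC(NS(=O)(=O)c2cc(S(=O)(=O)c3ccccc3)ccc2C(F)(F)F)CC1` gives 40 nM. The step of a 1.9-fold lower number from compound 1 to compound 2 (0.27 log units; within the scatter) stays within the scatter, whereas a 7.5-fold lower number from compound 1 to compound 3 (0.88 log units; beyond the scatter) and a 4.0-fold lower number from compound 2 to compound 3 (0.60 log units; beyond the scatter) lie beyond it. Compound 4 `O=C([C@@H]1CCCN1Cc1ccccc1)N1CCC(NS(=O)(=O)c2cc(S(=O)(=O)c3ccccc3)ccc2C(F)(F)F)CC1` has not yet been measured in this assay. It differs from compound 1 as follows: 1-benzylpyrrolidin-2-yl in place of (dimethylamino)methyl on a carbonyl carbon. The two measured steps from compound 1, a 1.9-fold lower number from compound 1 to compound 2 (0.27 log units; within the scatter) and a 7.5-fold lower number from compound 1 to compound 3 (0.88 log units; beyond the scatter), both exchange the same group for 1-acetylpyrrolidin-2-yl or 1-(isopropylcarbonyl)pyrrolidin-2-yl and both lower the number, the isopropylcarbonyl variant giving the larger drop. Going by the values given here, compound 4 carries 1-benzylpyrrolidin-2-yl instead, a change for which no measured step exists, so a modest lowering of the number in this assay is expected, estimated as a 3.3-fold lower number from compound 1 to compound 4 (0.52 log units; beyond the scatter). Compound 4 is therefore estimated at 90 nM in this assay, with an expected range from 25 nM to 350 nM.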

Compound 4, half-maximal inhibitory concentration: 1400 nM
For compound 4 the middle estimate is 16-fold (1.19 log units) below the measured one; the whole stated range lies below it.
By their numbers in this assay, from the lowest: compound 3; then compounds 2 and 1 (each within the scatter of the next); then compound 4.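

In this assay the 1-benzylpyrrolidin-2-yl group shows that a pyrrolidine ring on this carbonyl carbon does not by itself lower the number: this change brings a 4.7-fold higher number from compound 1 to compound 4 (0.67 log units; beyond the scatter) and is the only replacement of (dimethylamino)methyl shown that raises it. With the ring kept, the group on its amine nitrogen weighs heavily: benzyl in place of isopropylcarbonyl brings a 35-fold higher number from compound 3 to compound 4 (1.54 log units; beyond the scatter) and benzyl in place of acetyl brings an 8.8-fold higher number from compound 2 to compound 4 (0.94 log units; beyond the scatter) on the same ring. Nothing available explains why the benzyl compound behaves this way.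

The compounds shown leave open whether the loss follows the absence of a carbonyl on that nitrogen or the benzyl group itself, which a phenylacetyl or a plain methyl group there would help separate. They also leave open what the opposite stereocentre of the pyrrolidine ring would give.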